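The compounds below may be only part of what the source reports. "The series", "measured", "known", "first", "only" and "open" are said of these compounds alone.

Measured compounds:
- compound 1 `N=C(N)c1ccc(-c2ccc(-c3cc(Cl)cc(Cl)c3)s2)s1` — "non-toxic" (no number reported) (no number behind it)
- compound 2 `N=C(N)c1ccc(-c2ccc(-c3ccc(Cl)cc3)o2)o1` — 14%
- compound 3 `COc1cccc(-c2ccc(-c3ccc(C(=N)N)s3)s2)c1` — 3.1%

In an ADME assay on cells (Erythrocyte, Homo sapiens) for activation, read by hemolysis, with a stated time of 30 min, tested at 1.25 mM (on this read-out lower numbers stand for a weaker effect and higher numbers for a stronger effect at the one concentration tested), compound 2 gives 14%, the higher of the two numbers in the set. Compound 3 gives 3.1%, lower than compound 2 by more than the usual scatter. Compound 1 is reported in this assay only as "non-toxic" (no number reported), without a number, so it cannot be ordered against the other two.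

Compound 4 `N=C(N)c1ccc(-c2ccc(-c3ccc(F)cc3)o2)o1` has not been measured. It differs from compound 2 in one place: fluoro in place of chloro on an aromatic carbon. The exchange is fluoro in place of chloro on an aromatic carbon; nothing else in the structure moves. For the measured compounds named here, no pair of measured compounds shows this exchange, so the size of its step cannot be read from the data. The expectation for this assay is a small step, downward if anything, that may well stay within the scatter. Compound 4 is estimated at 10%, with a range from 2% to 22%. The step from compound 2 to compound 4 that this estimate means is a number 4 percentage points lower from compound 2 to compound 4 (within the scatter), an expected and not a measured quantity.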

Compound 4, a percentage reported as activity, at one concentration (the size of the read-out at that concentration, not a potency): "non-toxic" (no number reported)
The entry for compound 4 holds no number; the estimate stays without a comparison.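

For the compounds shown here, compound 4 holds no number in this assay and compound 2 gives 14% there, so no step between compound 2 and compound 4 can be read. The compounds shown leave open how large the effect of fluoro in place of chloro is on this read-out. No evidence bearing on this result is available.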